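The compounds below may be only part of what the source reports. "The series", "measured", "known", "first", "only" and "open" are said of these compounds alone.

Measured so far in an assay on isolated protein for binding affinity to adenosine receptor A1 (Bos taurus); on this read-out lower numbers stand for stronger inhibition and higher numbers for weaker inhibition:
- compound 1, `CCNc1nc(-c2ccccc2)nc2c1nnn2Cc1ccccc1Cl` — 463000000 nM
- compound 2, `CCCCNc1nc(-c2ccccc2)nc2c1nnn2Cc1ccccc1C(F)(F)F` — 6500000 nM
- compound 3, `CCCNc1nc(-c2ccccc2)nc2c1nnn2Cc1ccccc1` — 37000000 nM

Compound 1 gives the highest of the three numbers; compound 3 sits nearest to it and compound 2 furthest, both gaps lying beyond the scatter. Compounds 2 and 3 each differ from compound 1 in more than one place, so none of these gaps can be read as a single step.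

Compound 4, `Clc1ccccc1Cn1nnc2c(NC3CCC3)nc(-c3ccccc3)nc21`, is not yet measured. It differs from compound 1 in one place: cyclobutyl in place of ethyl on a nitrogen on an aromatic ring. Nothing measured isolates this change, so the expectation rests on the weak starting point of compound 1 at 463000000 nM and leaves wide room. A step from compound 1 to compound 4 of a 12-fold lower number from compound 1 to compound 4 (1.06 log units; beyond the scatter) is expected, toward a lower number. Compound 4 is estimated at 40000000 nM, within 4000000 nM to 400000000 nM.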

Compound 4, inhibition constant: 24000000 nM
The estimate for compound 4 lay 1.7-fold (0.22 log units) above the measured number; low and high end bracket the measured number.
By their numbers in this assay, from the lowest: compound 2; then compounds 4 and 3 (each within the scatter of the next); then compound 1.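

Among these compounds, on the nitrogen on an aromatic ring, cyclobutyl in place of ethyl gives a 19-fold lower number from compound 1 to compound 4 (1.29 log units; beyond the scatter) in this assay, the first change that can be read as a single step. The group on this nitrogen therefore matters to the read-out, and the step is large, although compound 4 still has a high number. No available evidence explains the step.

As far as these compounds go, it remains open whether the ring or the added carbon count carries the step. An isobutyl chain or a cyclopentyl group on this nitrogen, with the rest of compound 1 kept, would separate the two.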